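Furan-2-yl Amide on a Pyrazole Core: Expected Efficacy

The compounds below may be only part of what the source reports. "The series", "measured", "known", "first", "only" and "open" are said of these compounds alone.

Measured compounds:
compound 1, `CC(C)C(=O)N1CCCn2nc(COc3ccccc3)cc21`: 59%
compound 2, `O=C(c1ccccc1F)N1CCCn2nc(COc3ccccc3)cc21`: 62%

In a functional assay on HEK293 cells for positive allosteric modulation of metabotropic glutamate receptor 5 (Homo sapiens), read by calcium flux (a lower number here means a smaller maximal response, a higher number a larger maximal response), compound 1 gives 59%, the lowest of the two numbers, with compound 2 nearest at 62%; the two lie within the scatter of each other. Compound 3, `O=C(c1ccco1)N1CCCn2nc(COc3ccccc3)cc21`, is not yet measured. It differs from compound 1 in one place: furan-2-yl in place of isopropyl on a carbonyl carbon. Among the measured compounds shown here, the one measured step that bears on this, a number 3 percentage points higher from compound 1 to compound 2 (within the scatter), also replaced isopropyl on that carbonyl carbon with a ring, and it stayed within the scatter. The step of a number 1 percentage points higher from compound 1 to compound 3 (within the scatter) is therefore expected to be small, with no direction beyond the scatter. Compound 3 is expected to give 60% in this assay, within 45% to 75%.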

Compound 3, largest response reached (reported as percent of maximum), in percent of the reference or control that the assay uses: < 15%
Compound 3 was reported as a limit; the forecaster's own chance of this, stated with the estimate: 0%; at least 45 percentage points between middle value and limit.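

On this carbonyl carbon, the kind of ring matters and not merely the presence of one: in this assay 2-fluorophenyl gave a number 3 percentage points higher from compound 1 to compound 2 (within the scatter) while furan-2-yl gave a number at least 44 percentage points lower from compound 1 to compound 3 (beyond the scatter) in the same place. The two rings also stand far apart, with a number at least 47 percentage points lower from compound 2 to compound 3 (beyond the scatter) on exchanging one for the other. Compound 3 sits at a limit of the assay, so its value is not a number: the limit of < 15% in this assay, at which 1 of the 3 values shown sits.

The compounds shown do not tell what in the furan-2-yl group goes with this loss of response. Going by these compounds, whether thiophen-2-yl or unsubstituted phenyl on this carbonyl carbon keeps the response also remains open.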